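Halogen swap on the triazolyl phenyl group

This account rests on a few compounds, and the source may have more. Where it says the series, first, only, none or still open, it means among the compounds named here.

Measured so far in a functional assay on MCF7 cells (Homo sapiens) for antiproliferative activity, read by MTT assay, with a stated time of 48 h; on this read-out higher numbers stand for weaker inhibition and lower numbers for stronger inhibition:
Compound 1 `N#CC1=C(N)Oc2c(N)cc3nc4ccccc4nc3c2C12C(=O)N(Cc1cnnn1-c1ccc(Cl)cc1)c1ccccc12` gives only the assay limit > 50000 nM, not a number.
Compound 2 `N#CC1=C(N)Oc2c(N)cc3nc4ccccc4nc3c2C12C(=O)N(Cc1cnnn1-c1ccccc1Cl)c1ccccc12` gives 34400 nM.

Among the compounds with values here, compound 2 thus holds the only number in this assay; the other value is a limit (the limit of > 50000 nM in this assay, at which 1 of the 2 values shown sits). Within the data shown here, the single measured step, an at least 1.4-fold lower number from compound 1 to compound 2 (0.16 log units; that floor lies within the scatter), put 2-chlorophenyl in for 4-chlorophenyl, and its floor lies within the scatter. Compound 3 `N#CC1=C(N)Oc2c(N)cc3nc4ccccc4nc3c2C12C(=O)N(Cc1cnnn1-c1ccccc1Br)c1ccccc12` differs from compound 2 by bromo in place of chloro on an aromatic carbon. Among the measured compounds shown here, no measured step exchanges one halogen for another, so the only guide is the step from compound 1 to compound 2, which was small; a change of similar or smaller size is expected here, in no settled direction. Compound 3 is therefore expected to give about 30000 nM in this assay, between 12000 nM and 75000 nM. The expected step of a 1.1-fold lower number from compound 2 to compound 3 (0.06 log units; within the scatter) stays within the scatter.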

Compound 3, half-maximal inhibitory concentration: 30700 nM
The estimate for compound 3 lay 1.0-fold (0.01 log units) below the measured number; low and high end bracket the measured number.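

In this assay, bromo in place of chloro on an aromatic carbon, ortho to a large group, gives a 1.1-fold lower number from compound 2 to compound 3 (0.05 log units; within the scatter), so the two halogens cannot be told apart at this position on this read-out. This is the only halogen exchange shown, and it adds a second measured number to the series, so compound 2 no longer stands alone. The step to the 2-bromophenyl group is an at least 1.6-fold lower number from compound 1 to compound 3 (0.21 log units; that floor lies within the scatter), and it can be read only as a floor: the limit of > 50000 nM in this assay, at which 1 of the 3 values shown sits.

Going by these compounds, it remains open whether a fluoro, a methoxy or an amine in the same place would move the number beyond the scatter. On these data alone, it is also open whether 4-bromophenyl would give a measurable number or stay at the assay limit, as compound 1 does.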